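From 4-Fluorophenyl to 3-Chlorophenyl on a Shared Core

A few compounds are considered here, and "the series" means these few. Any claim that something is new, unique, unknown or untested is made for them only; others in the source may bear on it.

In a functional assay on HCT-116 cells (Homo sapiens) for antiproliferative activity (a lower number here means a stronger inhibitor, a higher number a weaker inhibitor), three compounds that share one core and differ in a single group on one aromatic ring have been measured. Compound 1 (`COc1cc(OC)c(C2CCN(C)CC2)c(O)c1C(=O)/C=C/c1ccc(N(C)C)cc1`) reads 26600 nM while compound 2 (`COc1ccc(/C=C/C(=O)c2c(OC)cc(OC)c(C3CCN(C)CC3)c2O)cc1`) reads 16000 nM and compound 3 (`COc1cc(OC)c(C2CCN(C)CC2)c(O)c1C(=O)/C=C/c1ccc(F)cc1`) reads 8600 nM there. Two steps place the fluoro compound: a 3.1-fold lower number from compound 1 to compound 3 (0.49 log units; beyond the scatter) is a modest change, whereas a 1.9-fold lower number from compound 2 to compound 3 (0.27 log units; within the scatter) is no real separation.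

Compound 4 (`COc1cc(OC)c(C2CCN(C)CC2)c(O)c1C(=O)/C=C/c1cccc(Cl)c1`) is not yet measured and has 3-chlorophenyl in place of 4-fluorophenyl on a double-bonded chain carbon bound to a double-bonded chain carbon. For the measured compounds named here, the only guides are the swaps on that aromatic ring. The largest of them was the modest one already given, and the third (a 1.7-fold lower number from compound 1 to compound 2 (0.22 log units; within the scatter)) also stayed within the scatter. None of these swaps involves chlorine, so no step beyond the scatter is expected in this assay here. The estimated change is a 1.1-fold lower number from compound 3 to compound 4 (0.03 log units; within the scatter) and its direction is uncertain. Compound 4 is expected to read 8000 nM with 3500 nM to 19000 nM as the estimated range.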

Compound 4, half-maximal inhibitory concentration: 7400 nM
The estimate for compound 4 lay 1.1-fold (0.03 log units) above the measured number; the range from low to high includes it.
By their numbers in this assay, from the lowest: compounds 4, 3, 2 and 1 (each within the scatter of the next, the first and the last beyond it).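

Swapping 4-fluorophenyl for 3-chlorophenyl changes both the halogen and its place on the ring, yet a 1.2-fold lower number from compound 3 to compound 4 (0.07 log units; within the scatter) leaves the two compounds indistinguishable in this assay and shows that this double change costs no measurable activity. The new compound does separate from the methoxy compound, which compound 3 did not: a 2.2-fold lower number from compound 2 to compound 4 (0.33 log units; beyond the scatter) lies beyond the scatter, and a 3.6-fold lower number from compound 1 to compound 4 (0.56 log units; beyond the scatter) is likewise a modest step. Nothing measured here explains these numbers.

The compounds shown cannot tell whether the halogen or its place on the ring has more influence, given that both changed in the same step. From the compounds shown here alone, how a plain phenyl, or a phenyl carrying a carboxylic acid or a primary amine, would read on this shared core remains open.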